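Chloro for Hydrogen on the Shared Core

This account rests on a few compounds, and the source may have more. Where it says the series, first, only, none or still open, it means among the compounds named here.

Measured so far:
compound 1 `ClCc1ccc(Cn2cnc3c(Cl)ncnc32)cc1` — 97700 nM
compound 2 `Nc1nc(Cl)c2ncn(Cc3ccccc3CCl)c2n1` — > 100000 nM, a limit of the assay
compound 3 `ClCc1cccc(Cn2cnc3nc(Cl)nc(Cl)c32)c1` — 38900 nM

In a functional assay on UACC-257 cells (Homo sapiens) for cytotoxicity, read by sulforhodamine B assay, with a stated time of 48 h (on this read-out higher numbers stand for lower toxicity in this test and lower numbers for higher toxicity in this test), compound 1 gives 97700 nM, the highest of the two numbers reported. Compound 3 gives 38900 nM, a gap from compound 1 that lies beyond the usual scatter. Compound 2 sits only at the limit of > 100000 nM in this assay, at which 1 of the 3 values shown sits.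

Compound 4 `ClCc1ccc(Cn2cnc3c(Cl)nc(Cl)nc32)cc1` differs from compound 1 by chloro in place of hydrogen on an aromatic carbon. Among the measured compounds shown here, compound 3, which also carries two chloro groups on its core, shows the lower number of the two measured compounds, but no step to compound 1 is measured. The step of a 1.6-fold lower number from compound 1 to compound 4 (0.21 log units; within the scatter) is expected to be small, toward a lower number, and hardly beyond the scatter. Compound 4 is therefore estimated at 60000 nM, within 25000 nM to 150000 nM.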

Compound 4, concentration lethal to 50% of the cells: 69200 nM
Beside the measured number, compound 4's estimate is 1.2-fold (0.06 log units) below it, within the range that was stated.
By their numbers in this assay, from the lowest: compounds 3, 4 and 1 (each within the scatter of the next, the first and the last beyond it). At a limit, above all of these: compound 2.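

Chloro in place of hydrogen on the aromatic carbon between two ring nitrogen atoms gives a 1.4-fold lower number from compound 1 to compound 4 (0.15 log units; within the scatter) in this assay and so no change that can be told apart from the scatter. Among the compounds shown here, this is the first step that changes one place only, and at this position it leaves the number where it was within that scatter. Nothing measured here gives a cause for this step.

On these data alone, whether a methoxy group or a nitrile at this position would move the number beyond the scatter stays open. Also open, as far as these compounds go, is whether any single change on the shared core would do so.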